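The source may report more compounds than this note shows. Statements on the series, on what has been measured and on what is new or still open speak of the compounds shown alone.

Measured compounds:

Compound 1 `CCCN(CCC)c1cc(C)nc2c(-c3ncc(C(F)(F)F)cc3Cl)c(C)nn12`: 1.2 nM
Compound 2 `CCCN(CCC)c1cc(C)nc2c(-c3ncc(C)cc3[N+](=O)[O-])c(C)nn12`: 14 nM
Compound 3 `CCCN(CCC)c1cc(C)nc2c(-c3ncc(NC)cc3C)c(C)nn12`: 40 nM

All three share one core and differ only in the groups carried on the attached pyridine ring. In an assay on isolated protein for binding affinity to corticotropin-releasing factor receptor 1 (Homo sapiens) (on this read-out lower numbers stand for stronger inhibition and higher numbers for weaker inhibition), compound 1 gives 1.2 nM, compound 2 gives 14 nM and compound 3 gives 40 nM. Compound 3 thus has the highest number of the three: its nearest neighbour is compound 2, whose number is lower by an amount beyond the usual scatter, and compound 1 lies far below it.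

Compound 4 `CCCN(CCC)c1cc(C)nc2c(-c3ncccc3C)c(C)nn12` has not yet been measured. It differs from compound 3 in one place: hydrogen in place of methylamino on an aromatic carbon. Among the measured compounds shown here, nothing among the measured pairs shows the effect of removing a group at this position outright, since no two of them differ in a single place. The measured values only show that the three substituted pyridines span a wide range in this assay, with compound 3 at the weak end.

Without a directly comparable step, the expectation is a modest change, more likely toward a higher number than a lower one, but possibly within the scatter; for compound 4 the expected value is 60 nM, between 20 nM and 200 nM, which would correspond to a step of a 1.5-fold higher number from compound 3 to compound 4 (0.18 log units; within the scatter).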

Compound 4, inhibition constant: 110 nM
Compound 4: the middle estimate sits 1.8-fold (0.26 log units) below what was measured; low and high end bracket the measured number.
By their numbers in this assay, from the lowest: compound 1; then compound 2; then compound 3; then compound 4.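

In this assay, among the compounds shown here, taking methylamino off the pyridine ring gives a 2.8-fold higher number from compound 3 to compound 4 (0.44 log units; beyond the scatter), the first comparison here between two compounds that differ in one place. The step shows that this position, two atoms from the ring nitrogen and para to a large group, affects the read-out: with the methyl group kept on the ring, methylamino goes with a lower number than hydrogen, by more than the usual scatter. The methylamino group's hydrogen-bond donor, hydrogen-bond acceptor and heavy atoms all leave together, and no measurement available here explains the change.

On these data alone, whether a plain amino group, a dimethylamino group or a methoxy group at this position would match methylamino, or give a number closer to that of hydrogen, stays open. As far as these compounds go, it also stays open whether the same step would appear if the methyl group were replaced by the chlorine of compound 1 or the nitro group of compound 2, since those compounds differ from compound 3 and compound 4 in more than one place.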